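A Methylsulfonyl Benzamide Joins a Weakly Active Series

A few compounds are considered here, and "the series" means these few. Any claim that something is new, unique, unknown or untested is made for them only; others in the source may bear on it.

Three amides sharing one core have been tested in a functional assay on MDA-MB-231 cells (Homo sapiens) for antiproliferative activity, read by MTT assay, with stated times of 72 h and 4 h; a lower number here means a stronger inhibitor, a higher number a weaker inhibitor. Compound 1 `O=C(Nc1ccc(Cl)c(-c2nnc3c(Cl)cccn23)c1)c1ccc(C(F)(F)F)cc1F` gives > 100000 nM, which is a limit of the assay rather than a number. Compound 3 `O=C(Nc1ccc(Cl)c(-c2nnc3c(Cl)cccn23)c1)c1ccc(C(F)(F)F)cc1Cl` likewise gives only the limit > 100000 nM. Compound 2 `O=C(Nc1ccc(Cl)c(-c2nnc3c(Cl)cccn23)c1)c1ccccc1Cl` gives 59900 nM and is the only one of the three with a measured number, since two of the three values sit at the limit of > 100000 nM in this assay, at which 2 of the 3 values shown sit. The step that the two limits leave unreadable from compound 1 to compound 3 is unreadable, while an at least 1.6-fold higher number from compound 2 to compound 3 (0.22 log units; that floor lies within the scatter) ran toward the limit. Compound 4 `CS(=O)(=O)c1ccc(C(=O)Nc2ccc(Cl)c(-c3nnc4c(Cl)cccn34)c2)cc1` differs from compound 2 in one place: 4-(methylsulfonyl)phenyl in place of 2-chlorophenyl on a carbonyl carbon. Going by the values given here, because the only readable change on this ring, an at least 1.6-fold higher number from compound 2 to compound 3 (0.22 log units; that floor lies within the scatter), weakened inhibition, no gain is expected here. Compound 4 is estimated at 100000 nM, ranging from 30000 nM to 300000 nM, a step of a 1.7-fold higher number from compound 2 to compound 4 (0.22 log units; within the scatter).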

Compound 4, half-maximal inhibitory concentration: > 100000 nM
Compound 4: a limit, no number; the forecaster's own chance of this, stated with the estimate: 55%; the middle value sits exactly at the limit.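

In this assay compound 4 gives a limit of the assay, not a number, so exchanging the whole ring on the carbonyl carbon for one with hydrogen-bond acceptors, which 2-chlorophenyl lacks, also yields no readable value. The change amounts to an at least 1.6-fold higher number from compound 2 to compound 4 (0.22 log units; that floor lies within the scatter), so no real loss can be claimed from it. The limit now holds most of the series: the limit of > 100000 nM in this assay, at which 3 of the 4 values shown sit.

Going by these compounds, whether an amine or a carboxylic acid on the ring at this carbonyl carbon would give a number clearly lower than that of compound 2 remains open.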